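Methoxy in place of chloro at one concentration

The source may report more compounds than this note shows. Statements on the series, on what has been measured and on what is new or still open speak of the compounds shown alone.

In a functional assay on HO8910 cells (Homo sapiens) for inhibition, read by MTT assay, with a stated time of 24 h, tested at 0.1 ug/mL (on this read-out lower numbers stand for less inhibition of growth and higher numbers for more inhibition of growth at the one concentration tested), compound 1 (`O=C(CCCCC1CCSS1)NO`) is reported as "not active" (no number reported), and compound 2 (`O=C(CCCCC1CCSS1)Nc1ccc([N+](=O)[O-])c(C(F)(F)F)c1`) is reported as "not active" (no number reported). Among the compounds with values here, compound 3 (`O=C(CCCCC(S)CCS)Nc1ccc(Cl)cc1`) gives 1.04%, the only number available, so no measured step shows how far such compounds move. Compound 4 (`COc1ccc(NC(=O)CCCCC(S)CCS)cc1`) carries methoxy in place of chloro on an aromatic carbon, para to a large group: methoxy in place of chloro on an aromatic carbon. Compound 3, at 1.04%, shows very little inhibition of growth, and nothing in the data points to a large gain. The expected a number 2 percentage points higher from compound 3 to compound 4 (within the scatter) stays within the usual scatter of this assay, with no clear direction. Compound 4 is expected at 3%, with an estimated range of 0% to 12%.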

Compound 4, percent growth inhibition at one concentration: "not active" (no number reported)
Compound 4 has no reported number here, and the estimate cannot be compared.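

Within the data shown here, compound 4 is reported without a number, and no step from compound 3 to compound 4 can be read. The compounds shown leave open how far methoxy in place of chloro moves growth inhibition. No evidence here bears on this result.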